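The source may hold more compounds than are shown below. What is called first, only, known or untested is meant among the compounds shown, and "the series" means these compounds.

Working notes on the series. In an ADME assay on A549 cells (Homo sapiens) for cytotoxicity, read by MTT assay (on this read-out lower numbers stand for higher toxicity in this test and higher numbers for lower toxicity in this test), compound 1 (`CCCCCCCCNc1ccn([C@H]2C[C@H](O)[C@@H](CO)O2)c(=O)n1`) gives 90000 nM and compound 2 (`CCCCCCNc1nc(=O)n([C@H]2C[C@H](O)[C@@H](CO)O2)cc1C`) gives 90000 nM. Compound 2 therefore stands level with compound 1, within the scatter. Among the compounds with values here, no measured pair differs in one place only, so the series offers no direct step to size the next change.

Compound 3 (`CCCCCCCCNc1nc(=O)n([C@H]2C[C@H](O)[C@@H](CO)O2)cc1C`) differs from compound 2 by one change: ethyl in place of hydrogen on a saturated chain carbon, six bonds along the chain from a nitrogen on an aromatic ring. This is ethyl in place of hydrogen on a saturated chain carbon, six bonds along the chain from a nitrogen on an aromatic ring.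

With compound 2 at 90000 nM and compound 1 showing the same value, no step beyond the scatter is expected in this assay. The estimated change, a 1.1-fold lower number from compound 2 to compound 3 (0.05 log units; within the scatter), leans only slightly toward lower numbers. For compound 3 the expected value is 80000 nM, with an estimated range of 35000 nM to 180000 nM.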

Compound 3, half-maximal cytotoxic concentration: 90000 nM
For compound 3 the middle estimate is 1.1-fold (0.05 log units) below the measured one, and the stated range covers the measured number.
By their numbers in this assay, from the lowest: compounds 1, 2 and 3 (each within the scatter of the next).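

In this assay, within the data shown here, the first direct reading at this position gives no change at the digits printed from compound 2 to compound 3 (within the scatter) for ethyl in place of hydrogen on a saturated chain carbon, six bonds along the chain from a nitrogen on an aromatic ring. The second direct reading, for methyl in place of hydrogen on an aromatic carbon, gives no change at the digits printed from compound 1 to compound 3 (within the scatter) and so shows that neither single change moves the read-out beyond the scatter in these pairs. No measurement here offers an explanation for either result. The compounds shown leave open whether a longer chain, or an amine or a carboxylic acid in place of the ethyl, would shift the value. With no step beyond the scatter so far, they also do not show which part of the structure, if any, governs the read-out in this assay in this series.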